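The compounds below may be only part of what the source reports. "The series", "measured", "known", "first", "only" and "open" are said of these compounds alone.

Measured compounds:
compound 1, `O=c1[nH]c2ccccc2n1C/C=C/CN1CCN(C(c2ccccc2)c2ccccc2)CC1`: > 10000 nM in an assay on RPMI-8226 cells for antagonist activity at P2X purinoceptor 7 (Homo sapiens), read by calcium flux; on this read-out lower numbers stand for stronger inhibition and higher numbers for weaker inhibition
compound 2, `Cc1cc2ncn(CCCCN3CCN(C(c4ccccc4)c4ccccc4)CC3)c2cc1C`: 770 nM

The account follows the step from compound 2 to compound 3. In this assay, among the compounds with values here, compound 2 gives 770 nM, and this is the only numerical value among the two compounds measured. For compound 1 the result is a limit of this assay, not a number, namely > 10000 nM; one of the two values shown sits at this limit (the limit of > 10000 nM in this assay, at which 1 of the 2 values shown sits). Within the data shown here, compound 2 therefore stands alone as the only compound with a measured number, and no step between measured compounds can be sized.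

Compound 3, `Fc1ccc2ccn(CCCCN3CCN(C(c4ccccc4)c4ccccc4)CC3)c2c1`, differs from compound 2 in one place: 6-fluoro-1H-indol-1-yl in place of 5,6-dimethyl-1H-benzimidazol-1-yl on a saturated chain carbon, four bonds along the chain from an amine nitrogen in a ring. The group that enters carries one hydrogen-bond acceptor where the group that leaves carried two, and a fluorine takes the place of the two methyl groups. Among the measured compounds shown here, no measured step within these compounds bears on such a change, so the direction cannot be read from the data.

The expected step from compound 2 to compound 3 is a 1.9-fold higher number from compound 2 to compound 3 (0.29 log units; within the scatter), a modest weakening that may still lie within the scatter. Compound 3 is estimated to give 1500 nM in this assay, with a range from 400 nM to 6000 nM.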

Compound 3, half-maximal inhibitory concentration: 110 nM
Estimate against measurement, compound 3: 14-fold (1.13 log units) above, outside the stated range (below it).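

Within the data shown here, the step from the benzimidazolyl to the indolyl group, a 7.0-fold lower number from compound 2 to compound 3 (0.85 log units; beyond the scatter), is the first sized change in this assay, and it shows that the number responds to the group carried on this saturated chain carbon, four bonds along the chain from an amine nitrogen in a ring. Among these compounds, the change is a bundled one: 6-fluoro-1H-indol-1-yl brings a fluorine and one hydrogen-bond acceptor, whereas 5,6-dimethyl-1H-benzimidazol-1-yl carried two methyl groups and two hydrogen-bond acceptors, so the single step cannot assign the gain to any one of these differences. Nothing measured here accounts for the size or direction of this step.

On these data alone, whether the second ring nitrogen, the fluorine or the methyl groups carry the effect remains open, and 5,6-dimethyl-1H-indol-1-yl or 6-fluoro-1H-benzimidazol-1-yl in the same place would separate these. How a shorter or longer chain, or a 6-chloro-1H-indol-1-yl group, would read on the same scale is also left open.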